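The source may hold more compounds than are shown below. What is called first, only, known or untested is meant among the compounds shown, and "the series" means these compounds.

Working notes on the series. In a functional assay on B16-F0 cells (Mus musculus) for inhibition, read by CCK-8 assay, with a stated time of 48 h (a higher number here means a weaker inhibitor, a lower number a stronger inhibitor), compound 1 `COc1cc(-c2ccnc3cc(-c4ccc(Cl)cc4)nn23)cc(OC)c1OC` gives 4090 nM, the low end of the two numbers shown. Compound 2 `Cn1ccc2cc(-c3cc4nccc(-c5ccc(F)cc5)n4n3)ccc21` gives 4780 nM in this assay, a gap from compound 1 that sits within the scatter. Compound 3 `COc1cc(-c2ccnc3c(-c4ccc(C)cc4)cnn23)cc(OC)c1OC` returns only a limit, > 10000 nM, in this assay; note (the limit of > 10000 nM in this assay, at which 1 of the 3 values shown sits). Compound 4 `COc1cc(-c2ccnc3cc(-c4ccc(C(C)(C)C)cc4)nn23)cc(OC)c1OC` is not yet measured in this assay. It differs from compound 1 by tert-butyl in place of chloro on an aromatic carbon, on the same core as compound 1. Among the compounds with values here, no measured pair here isolates such a change, so the step from compound 1 to compound 4 is expected to be small, a 1.5-fold higher number from compound 1 to compound 4 (0.17 log units; within the scatter), toward a higher number or none beyond the scatter. Compound 4 is estimated at 6000 nM, with a range from 2000 nM to 15000 nM.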

Compound 4, half-maximal inhibitory concentration: > 10000 nM
Compound 4: no number, only a limit; the forecaster's own chance of this, stated with the estimate: 30%; at least 1.6-fold (0.22 log units) between middle value and limit.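

Within the data shown here, this is the first single-place change: on this aromatic carbon, tert-butyl in place of chloro gives an at least 2.4-fold higher number from compound 1 to compound 4 (0.38 log units; beyond the scatter) in this assay and so the position does not take both groups alike. Compound 4 returns only a limit, which leaves the true size of the step unknown: the limit of > 10000 nM in this assay, at which 2 of the 4 values shown sit.

With a single step at this carbon, no trend across groups can be drawn. As far as these compounds go, whether an amine, a carboxylic acid or a nitrile here would keep the number near that of compound 1 stays open.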